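Fluoro in Place of Methyl: Expected Rat Exposure

The source may report more compounds than this note shows. Statements on the series, on what has been measured and on what is new or still open speak of the compounds shown alone.

Compound 3 `Cc1ccc(Cc2cc(Nc3nc(C)cn4c(-c5cn[nH]c5)cnc34)sn2)nc1` is the compound from which a new analogue is drawn. In an ADME assay on the whole organism for pharmacokinetics, with Rattus norvegicus as the target, with a stated time of 6 h, at a dose of 10 mg/kg by the oral route (on this read-out higher numbers stand for higher exposure at the dose given and lower numbers for lower exposure), compound 3 gives 1370 ng.h/mL, the highest of the two numbers available; compound 2 `Cc1cn2c(-c3cn[nH]c3)cnc2c(Nc2cc(Cc3ncccc3C)ns2)n1` gives 644 ng.h/mL, and compound 1 `Cc1cn2c(-c3cn[nH]c3)cnc2c(Nc2cc(Cc3ccncc3)ns2)n1` gives "not determined" (no result reported). Going by the values given here, the only measured step, a 2.1-fold higher number from compound 2 to compound 3 (0.33 log units; beyond the scatter), concerns where a methyl sits and not whether it is there at all. Compound 4 `Cc1cn2c(-c3cn[nH]c3)cnc2c(Nc2cc(Cc3ccc(F)cn3)ns2)n1` differs from compound 3 by fluoro in place of methyl on an aromatic carbon. Among the compounds with values here, no measured step bears directly on this change, so the expectation rests on the neighbouring numbers alone: a step of about a 1.4-fold lower number from compound 3 to compound 4 (0.14 log units; within the scatter), within the scatter, is expected. Compound 4 is therefore estimated at 1000 ng.h/mL, with a range from 400 ng.h/mL to 2500 ng.h/mL.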

Compound 4, area under the concentration-time curve: 2240 ng.h/mL
For compound 4 the middle estimate is 2.2-fold (0.35 log units) below the measured one, within the range that was stated.
By their numbers in this assay, from the lowest: compound 2; then compounds 3 and 4 (each within the scatter of the next).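

In this assay the methyl of the 5-methylpyridin-2-yl group can be exchanged for fluoro, with a 1.6-fold higher number from compound 3 to compound 4 (0.21 log units; within the scatter) showing that the two compounds cannot be told apart on this read-out. The step of a 3.5-fold higher number from compound 2 to compound 4 (0.54 log units; beyond the scatter) then shows that the gain over the 3-methylpyridin-2-yl group does not require a methyl at this position. Nothing available explains why either step has its size. From the compounds shown here alone, whether a chloro, a methoxy or an amine at the same position would keep this exposure stays open.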